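Sulfonyl anilide series: cytotoxicity limits and a piperazine analogue

The compounds below may be only part of what the source reports. "The series", "measured", "known", "first", "only" and "open" are said of these compounds alone.

Compound 1 `O=C(Nc1ccc(S(=O)(=O)N2CCCC2)cc1)c1ccc(C(F)(F)F)cc1` gives in an ADME assay on Vero cells (Chlorocebus sabaeus) for cytotoxicity, read by MTT assay (on this read-out lower numbers stand for higher toxicity in this test and higher numbers for lower toxicity in this test), only the limit > 300000 nM.
Compound 2 `Cn1nc(C(F)(F)F)cc1C(=O)Nc1ccc(S(=O)(=O)N2CCC[C@H]2C(=O)O)cc1` gives in this assay only the limit > 300000 nM.
Compound 3 `Cn1nc(C(F)(F)F)cc1C(=O)Nc1ccc(S(=O)(=O)N2CCCCC2)cc1` gives in this assay only the limit > 300000 nM.

Compound 3 stands where every measured member stands: at the limit of this assay, with no number of its own. Among the measured compounds shown here, the one step that can be traced within the measured set, a step that the two limits leave unreadable from compound 2 to compound 3, is hidden by two limits and gives no size. All that can be stated is the limit of > 300000 nM in this assay, at which 3 of the 3 values shown sit.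

Compound 4 `Cn1nc(C(F)(F)F)cc1C(=O)Nc1ccc(S(=O)(=O)N2CCNCC2)cc1` differs from compound 3 in one place: piperazin-1-yl in place of piperidin-1-yl on a sulfonyl sulfur. For the measured compounds named here, no measured step bears on this change; the only guidance is that the measured set contains no value readable below the limit. The expectation for compound 4 is therefore that a step that the limit leaves unreadable from compound 3 to compound 4 lies within the scatter, with no readable step in either direction. Compound 4 is estimated at 400000 nM, in the range 200000 nM to 1000000 nM, most likely again reported only as a limit.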

Compound 4, half-maximal cytotoxic concentration: 126000 nM
The estimate for compound 4 lay 3.2-fold (0.50 log units) above the measured number; measured number outside the range, below it.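

In this assay this position on the sulfonyl sulfur can carry a readable change: piperazin-1-yl in place of piperidin-1-yl gives an at least 2.3-fold lower number from compound 3 to compound 4 (0.37 log units; beyond the scatter). The same group in place of 2-carboxypyrrolidin-1-yl gives an at least 2.3-fold lower number from compound 2 to compound 4 (0.37 log units; beyond the scatter), and both steps are bounded on one side only, since each starts from a limit. Among the compounds shown here, compound 4 is thus the only member of the series with a number of its own: the limit of > 300000 nM in this assay, at which 3 of the 4 values shown sit.

From the compounds shown here alone, how far compound 2 and compound 3 truly lie from compound 4 stays open, so the full size of both steps is unknown. Also open, going by these compounds, is whether morpholin-4-yl or 4-methylpiperazin-1-yl on the same sulfonyl sulfur would stay at the limit or give a readable number like that of compound 4.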